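Phenyl to 4-chlorophenyl on compound 3

The source may hold more compounds than are shown below. What is called first, only, known or untested is meant among the compounds shown, and "the series" means these compounds.

Values in a functional assay on DLD-1 cells (Homo sapiens) for antiproliferative activity, read by CellTiter-Glo, with a stated time of 72 h (a higher number here means a weaker inhibitor, a lower number a stronger inhibitor), for the compounds measured so far:
- Compound 1 `CC1CCN(C2CCN(S(=O)(=O)c3ccc(C#N)cc3)CC2)CC1` gives 2800 nM
- Compound 2 `Cc1cc(C)c(S(=O)(=O)N2CCC(N3CCN(C)CC3)CC2)c(C)c1` gives 1100 nM
- Compound 3 `CC1CCN(C2CCN(S(=O)(=O)c3ccc(-c4ccccc4)cc3)CC2)CC1` gives 258 nM

Compound 3 (258 nM) has the lowest number of the three, with compound 2 (1100 nM) and compound 1 (2800 nM) both higher by more than the scatter. The next compound, compound 4 `CC1CCN(C2CCN(S(=O)(=O)c3ccc(-c4ccc(Cl)cc4)cc3)CC2)CC1`, differs from compound 3 in one place: chloro in place of hydrogen on an aromatic carbon with chloro in place of hydrogen on an aromatic carbon, para to a large group.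

Within the data shown here, the only measured step that bears on this is an 11-fold lower number from compound 1 to compound 3 (1.04 log units; beyond the scatter) when phenyl takes the place of cyano on an aromatic carbon. Among the measured compounds shown here, that step is large, but it swaps a whole group, and no measured pair shows what adding chloro does. In this assay the expected move is therefore small and toward a lower number, estimated as a 1.7-fold lower number from compound 3 to compound 4 (0.24 log units; within the scatter) and perhaps no larger than the scatter. For compound 4 the estimated value is 150 nM with an expected range from 60 nM to 400 nM as the likely span.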

Compound 4, half-maximal inhibitory concentration: 105 nM
Estimate against measurement, compound 4: 1.4-fold (0.15 log units) above; the measured number falls inside the stated range.
By their numbers in this assay, from the lowest: compound 4; then compound 3; then compound 2; then compound 1.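

Among these compounds, with chloro in place of hydrogen on an aromatic carbon, para to a large group, this assay records a 2.5-fold lower number from compound 3 to compound 4 (0.39 log units; beyond the scatter) and this is the first measured step that adds a single atom instead of swapping a whole group. It shows that this position can carry a substituent while the number still falls beyond the scatter, and the full change of cyano to 4-chlorophenyl gives a 27-fold lower number from compound 1 to compound 4 (1.43 log units; beyond the scatter) in the same assay. No measurement shown here accounts for this shift.

A single chloro cannot separate an effect of chloro itself from that of any other group at this place, such as fluoro, methyl, methoxy, an amine or a carboxylic acid. As far as these compounds go, whether chloro elsewhere on the same ring would lower the number as well also remains open.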